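The compounds below may be only part of what the source reports. "The series", "measured", "known", "first", "only" and "open" are said of these compounds alone.

Compound 1 `O=C(CCCCCCNC(=O)C(O)(O)C(F)(F)F)Nc1ccncc1` is the strongest of the two numbered results here: in a functional assay on HCT-116 cells (Homo sapiens) for inhibition, read by colorimetric assay, with a stated time of 3 days (on this read-out higher numbers stand for weaker inhibition and lower numbers for stronger inhibition), compound 1 gives 6670 nM. Its nearest neighbour is compound 3 `O=C(CCCCCCCNC(=O)C(O)(O)C(F)(F)F)Nc1ccccc1`, which carries the trifluoromethyl hydrate amide on a longer chain and a plain phenyl amide; in this assay compound 3 gives 41700 nM, a gap from compound 1 that lies beyond the usual scatter. Compound 2 `O=C(CCCCCNC(=O)c1cc(=O)c(O)co1)Nc1ccccc1` bears a different acyl group altogether. For compound 2 the read-out in this assay is a limit of the assay, > 100000 nM, rather than a number (the limit of > 100000 nM in this assay, at which 1 of the 3 values shown sits).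

Compound 4 `O=C(CCCCCCNC(=O)C(O)(O)C(F)(F)F)Nc1ccc(F)cc1` is built from compound 1 by a single exchange: 4-fluorophenyl in place of pyridin-4-yl on an amide-type nitrogen. For the measured compounds named here, no measured pair in this set separates this ring change from a change in chain length, so the direction must be inferred from compound 1 and compound 3 alone, whose values differ in both respects. The author expects the step from compound 1 to compound 4 to go toward weaker inhibition in this assay, of moderate size, a 2.2-fold higher number from compound 1 to compound 4 (0.35 log units; beyond the scatter), and beyond the scatter. Accordingly compound 4 is estimated to give 15000 nM in this assay, with a plausible range from 4000 nM to 60000 nM.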

Compound 4, half-maximal inhibitory concentration: 7570 nM
Beside the measured number, compound 4's estimate is 2.0-fold (0.30 log units) above it, and the stated range covers the measured number.
By their numbers in this assay, from the lowest: compounds 1 and 4 (each within the scatter of the next); then compound 3. At a limit, above all of these: compound 2.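

In this assay, the exchange of pyridin-4-yl for 4-fluorophenyl on an amide-type nitrogen gives a 1.1-fold higher number from compound 1 to compound 4 (0.05 log units; within the scatter), so the two compounds cannot be told apart on this read-out. For the compounds shown here, this is the first pair in the set that differs in one place, and it shows that, on the chain shared by compound 1 and compound 4, this place accepts a six-membered aromatic ring of carbon only as readily as a ring containing nitrogen; the ring nitrogen of compound 1 is therefore not needed for its level of inhibition here. Nothing given here offers a measured reason for this result.

The compounds shown do not separate the effect of chain length from that of the ring, and a plain phenyl amide on the chain of compound 1 would settle that question directly. Going by these compounds, it also remains open whether this place tolerates other groups to the same degree, such as a methoxy group or a nitrile on the ring, or a carboxylic acid in place of the fluorine.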